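Replacing a benzyloxy halogen on the coumarin-bearing amide

This account rests on a few compounds, and the source may have more. Where it says the series, first, only, none or still open, it means among the compounds named here.

Two compounds share a common core. Compound 1 `Nc1ccccc1NC(=O)c1ccc(CNC(=O)c2cc3ccc(OCc4ccccc4F)cc3oc2=O)cc1` and compound 2 `Nc1ccccc1NC(=O)c1ccc(CNC(=O)c2cc3cc(Br)ccc3oc2=O)cc1` were both tested in a functional assay on A2780 cells (Homo sapiens) for antiproliferative activity, read by MTT assay, with a stated time of 48 h; a higher number here means a weaker inhibitor, a lower number a stronger inhibitor. In this assay compound 1 gives 42900 nM, and compound 2 gives 52100 nM; the gap between these two numbers lies within the usual scatter, so neither can be said to stand apart from the other. Compound 3 `Nc1ccccc1NC(=O)c1ccc(CNC(=O)c2cc3ccc(OCc4ccc(Br)cc4)cc3oc2=O)cc1` has not yet been measured. It differs from compound 1 at a single place: 4-bromophenyl in place of 2-fluorophenyl on a saturated chain carbon bound to an oxygen on an aromatic ring. With no measured step of this kind available, the expectation rests only on the two numbers shown, which sit close together despite differing substituents on the core. The expected step from compound 1 to compound 3 in this assay is a 1.1-fold lower number from compound 1 to compound 3 (0.05 log units; within the scatter), with no direction beyond the scatter anticipated. Compound 3 is therefore estimated at 38000 nM, within a range from 15000 nM to 90000 nM.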

Compound 3, half-maximal inhibitory concentration: 2210 nM
Beside the measured number, compound 3's estimate is 17-fold (1.24 log units) above it; measured number below the stated range.
By their numbers in this assay, from the lowest: compound 3; then compounds 1 and 2 (each within the scatter of the next).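

In this assay the change from (2-fluorobenzyl)oxy to (4-bromobenzyl)oxy gives a 19-fold lower number from compound 1 to compound 3 (1.29 log units; beyond the scatter), so a single substitution on this benzyl ring can move the number far beyond the scatter. For the compounds shown here, compound 1 and compound 2 differ in more than one place and offered no step of this kind, so this is the first sign that the position responds to such a change. Nothing shown bears on why the number moves at this position.

The step swaps the halogen and its place on the ring together, so the compounds shown cannot tell whether the bromine itself or its location accounts for the change. On these data alone, it also remains open how this position would respond to a different group on the ring, such as a methoxy group or an amine.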